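The compounds below may be only part of what the source reports. "The series", "measured", "known", "first", "only" and "open" are said of these compounds alone.

Measured compounds:
Compound 1, `C#CCN(CC)Cc1cn(-c2cc(NC(=S)NCC)ncn2)cn1` — in an assay on isolated protein for inhibition of Amine oxidase [flavin-containing] B (Homo sapiens), read by fluorescence and Amplex Red, with a stated time of 15 min (a lower number here means a stronger inhibitor, a higher number a weaker inhibitor), compound 1 gives > 50000 nM, a limit of the assay.
Compound 2, `C#CCN(CCCC)Cc1cn(-c2cc(NC(=S)NCC)ncn2)cn1` — in this assay compound 2 gives > 50000 nM, again a limit.
Compound 3, `C#CCN(Cc1cn(-c2cc(NC(=S)NCC)ncn2)cn1)C(C)=O` — in this assay compound 3 gives > 50000 nM, also a limit.

Compound 1 thus stands at a limit, not at a measured number. The unmeasured compound 4, `C#CCN1CCN(Cc2cn(-c3cc(NC(=S)NCC)ncn3)cn2)CC1`, differs from it by 4-propargylpiperazin-1-yl in place of ethyl(propargyl)amino on a saturated chain carbon bound to an aromatic carbon. For the measured compounds named here, the steps that bear on this change, both at the amine nitrogen, are a step that the two limits leave unreadable from compound 1 to compound 2 and a step that the two limits leave unreadable from compound 1 to compound 3; their sizes cannot be read because of the limit of > 50000 nM in this assay, at which 3 of the 3 values shown sit. Going by the values given here, no measured step therefore says how far changing the amine nitrogen moves the value, and no direction can be expected beyond the scatter. For compound 4 the estimate is 60000 nM, ranging from 15000 nM to 300000 nM. The step that the limit leaves unreadable from compound 1 to compound 4 that this estimate implies is expected to be essentially none, with the likeliest outcome that compound 4 is again reported only as a limit.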

Compound 4, half-maximal inhibitory concentration: > 50000 nM
Compound 4: only a limit was reported (the forecaster's own chance of this, stated with the estimate: 80%); the middle value lies beyond the limit too.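

For the compounds shown here, compound 4, like compound 1, compound 2 and compound 3, is reported only as a limit, so no step among them can be read: the limit of > 50000 nM in this assay, at which 4 of the 4 values shown sit. From the compounds shown here alone, what stays open is whether any change at the amine nitrogen gives a measurable value in this assay at all.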